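The source may hold more compounds than are shown below. What is called first, only, known or untested is meant among the compounds shown, and "the series" means these compounds.

Working notes on the series, read in a functional assay (aorta) for inhibition, with Rattus norvegicus as the target; a higher number here means a weaker inhibitor, a lower number a stronger inhibitor. Compound 1 `Cc1nsc(-c2nccc(N3CCN(c4cccc(C(F)(F)F)c4)CC3)n2)n1` gives > 100 nM, which is a limit of the assay and not a number. Compound 2 `Cc1nsc(-c2ccnc(N3CCN(c4cccc(C(F)(F)F)c4)CC3)n2)n1` gives > 100 nM, also a limit. Within the data shown here, compound 3 `CCc1nsc(-c2ccc(N3CCN(c4cccc(C(F)(F)F)c4)CC3)nn2)n1` gives 8 nM, the only true number so far. The other two readings amount to the limit of > 100 nM in this assay, at which 2 of the 3 values shown sit.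

Compound 4 `CNc1nsc(-c2ccc(N3CCN(c4cccc(C(F)(F)F)c4)CC3)nn2)n1` keeps the structure of compound 3 except for one place, with methylamino in place of ethyl on an aromatic carbon.

Among the measured compounds shown here, no measured pair isolates this change, so its size is not known from the data. Compound 3 at 8 nM is the sole numerical anchor, and a modest loss of strength in this assay is expected. The expected change is a 1.9-fold higher number from compound 3 to compound 4 (0.27 log units; within the scatter), which may not clear the usual scatter by much. Compound 4 is estimated at 15 nM, with an expected range of 4 nM to 60 nM.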

Compound 4, half-maximal inhibitory concentration: 3 nM
Compound 4: middle estimate off by 5.0-fold (0.70 log units), on the high side; the whole stated range lies above it.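

In this assay, among these compounds, methylamino in place of ethyl gives a 2.7-fold lower number from compound 3 to compound 4 (0.43 log units; beyond the scatter), the only step that isolates a single change. The position, on an aromatic carbon between two ring nitrogen atoms, therefore takes a nitrogen-linked group as well as ethyl without loss of strength; both groups have 2 heavy atoms, while methylamino brings 1 hydrogen-bond donor and 1 hydrogen-bond acceptor. Nothing measured here bears on why the number falls.

As far as these compounds go, it remains open whether the nitrogen or its hydrogen accounts for the step: dimethylamino at this place would bear on that, while an unsubstituted amine or a longer chain such as propylamino would show how far the trend extends. Compounds 1 and 2 differ from compound 3 in more than one place and add nothing on this position.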